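The source may report more compounds than this note shows. Statements on the series, on what has been measured and on what is new or still open speak of the compounds shown alone.

Measured so far:
Compound 1, `Nc1cc(Cc2ccn(Cc3ccccc3)n2)c2nn[nH]c2n1`: 2300 nM
Compound 2, `Nc1cc(Cc2ccn(Cc3cccc(Oc4ccccc4)c3)n2)c2nn[nH]c2n1`: 1100 nM

Both numbers come from an assay on cells for inhibition of thyroid peroxidase (Homo sapiens), with stated times of 10 min and 15 min; a lower number here means a stronger inhibitor, a higher number a weaker inhibitor. Compound 2 has the lower of the two numbers, and its nearest neighbour is compound 1, separated by a 2.1-fold lower number from compound 1 to compound 2 (0.32 log units; beyond the scatter), which came with phenoxy in place of hydrogen on an aromatic carbon.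

Compound 3, `Nc1cc(Cc2ccn(Cc3cccc(O[C@H]4CCNC4)c3)n2)c2nn[nH]c2n1`, keeps that oxygen but changes what hangs on it: pyrrolidin-3-yl in place of phenyl on an oxygen on an aromatic ring. Among the compounds with values here, the only measured step bears on it indirectly, showing that the group at this oxygen position can move the number, but by a modest amount; no measured pair shows pyrrolidin-3-yl against phenyl. The step from compound 2 to compound 3 is therefore expected to be small, with a slight lean toward a higher number, as a 1.6-fold higher number from compound 2 to compound 3 (0.21 log units; within the scatter). Compound 3 is estimated at 1800 nM, within a range from 600 nM to 5500 nM.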

Compound 3, half-maximal inhibitory concentration: 14000 nM
Compound 3: the middle estimate sits 7.8-fold (0.89 log units) below what was measured; the measured number lies above the stated range.
By their numbers in this assay, from the lowest: compound 2; then compound 1; then compound 3.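

In this assay, the group on this oxygen matters far more than the earlier step suggested: pyrrolidin-3-yl in place of phenyl gives a 13-fold higher number from compound 2 to compound 3 (1.10 log units; beyond the scatter) on a change of a single ring. Adding a group at this aromatic carbon also does not push the number one way: phenoxy gave a 2.1-fold lower number from compound 1 to compound 2 (0.32 log units; beyond the scatter) while (pyrrolidin-3-yl)oxy gives a 6.1-fold higher number from compound 1 to compound 3 (0.78 log units; beyond the scatter) for the same starting compound. Nothing available explains why these two groups part so widely.

From the compounds shown here alone, whether the higher number goes with the nitrogen of pyrrolidin-3-yl or with the loss of the aromatic ring remains open, and cyclopentyl on the same oxygen would tell the two apart. The mirror-image form of pyrrolidin-3-yl also remains an open question.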